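Adding a Second Methyl Group: From Compound 2 to Compound 3

The source may hold more compounds than are shown below. What is called first, only, known or untested is meant among the compounds shown, and "the series" means these compounds.

Measured so far:
compound 1 `O=C(/C=C/CCc1ccccc1Br)c1ccccc1` — 1640 nM
compound 2 `Cc1ccccc1C(=O)/C=C/CCc1ccccc1` — 2630 nM

The two compounds measured share a core that carries a ketone joined to an unsaturated chain ending in a phenyl group. In a functional assay on HEK293 cells for antagonist activity at G-protein coupled receptor 52 (Homo sapiens), read by cAMP accumulation, with stated times of 15 min and 30 min (a lower number here means a stronger inhibitor, a higher number a weaker inhibitor), compound 1 gives 1640 nM. In this assay compound 2 gives 2630 nM, the higher of the two numbers, though the gap to compound 1 lies within the scatter of repeated measurements, so the two values cannot be told apart with confidence.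

Compound 3 `Cc1cccc(C)c1C(=O)/C=C/CCc1ccccc1` has not yet been measured. It differs from compound 2 in one place: methyl in place of hydrogen on an aromatic carbon. In words, a methyl group takes the place of a hydrogen on an aromatic carbon of a six-membered aromatic ring of carbon only, ortho to a large group and meta to a methyl group, so that the ring now carries two methyl groups around the ketone.

Within the data shown here, no step between measured compounds exists to guide this change. The expectation is a step of a 1.1-fold higher number from compound 2 to compound 3 (0.06 log units; within the scatter) in this assay, not beyond the scatter. For compound 3 the estimate in this assay is 3000 nM, within 1200 nM to 8000 nM.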

Compound 3, half-maximal inhibitory concentration: 2820 nM
Estimate against measurement, compound 3: 1.1-fold (0.03 log units) above; the range from low to high includes it.
By their numbers in this assay, from the lowest: compounds 1, 2 and 3 (each within the scatter of the next).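

In this assay, among these compounds, putting methyl in place of hydrogen on an aromatic carbon gives a 1.1-fold higher number from compound 2 to compound 3 (0.03 log units; within the scatter) and is the first single change that can be read as a step. This position, ortho to a large group and meta to a methyl group, therefore accepts a methyl group without a shift that can be told apart from the ordinary spread of repeated measurements, so adding this one carbon neither gains nor loses anything measurable in this assay. Nothing measured alongside these numbers speaks to why the result comes out this way.

The compounds shown leave open whether a different group on this same aromatic carbon, such as an amine, a carboxylic acid or a longer chain, would move the number beyond the scatter, since methyl is the only group seen here in place of that hydrogen. They also leave open what the bromine of compound 1 would do on a ring that carries the methyl groups of compound 3, as no pair shown isolates that combination.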